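This account rests on a few compounds, and the source may have more. Where it says the series, first, only, none or still open, it means among the compounds named here.

Compound 1 `Cn1c(-c2ccccc2F)cnc1NC(=O)c1ccc(F)cc1` was examined in a toxicity assay on THP-1 cells (Homo sapiens) for inhibition; on this read-out lower numbers stand for higher toxicity in this test and higher numbers for lower toxicity in this test. In this assay compound 1 gives only a limit, > 100000 nM, and not a number. A related compound, compound 2 `COc1ccc(CNC(=O)NC(=O)c2ccc(F)cc2)cc1`, was examined in the same way. In this assay compound 2 also returns only a limit, > 50000 nM. Compound 1 therefore stands at one of the two limits on record, (the limit of > 100000 nM in this assay, at which 1 of the 2 values shown sits). The other value on record is likewise a limit, (the limit of > 50000 nM in this assay, at which 1 of the 2 values shown sits), so no ordering between the two compounds can be read from these numbers. Compound 3 `COc1ccc(-c2cnc(NC(=O)c3ccc(F)cc3)n2C)cc1` has not yet been measured. It differs from compound 1 in one place: 4-methoxyphenyl in place of 2-fluorophenyl on an aromatic carbon. Among the measured compounds shown here, no measured pair isolates this change, so its effect on toxicity in this assay is unknown. Since compound 1 rests at the limit of > 100000 nM in this assay, at which 1 of the 2 values shown sits, the step from compound 1 to compound 3 is expected to be a number no higher from compound 1 to compound 3 (the limit leaves the size open), meaning no shift beyond the scatter, with a good chance that the assay again reports only a limit. Compound 3 is accordingly estimated at 100000 nM in this assay, within a range from 30000 nM to 300000 nM.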

Compound 3, half-maximal cytotoxic concentration: >= 50000 nM
Compound 3 gave a limit, no number (the forecaster's own chance of this, stated with the estimate: 70%); the middle value is on the limit's open side.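

Compound 1 and compound 3 both return only limits in this assay, so the step between them, 4-methoxyphenyl in place of 2-fluorophenyl, cannot be read. The compounds shown leave open where any of them would give an actual number, and whether this change on the aromatic carbon shifts the read-out at all.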